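Nitro to amino on the aryl of compound 1

The source may hold more compounds than are shown below. What is called first, only, known or untested is meant among the compounds shown, and "the series" means these compounds.

Going by the values given here, compound 1 `COC(=O)c1ccc([N+](=O)[O-])c(-c2nc3ccccc3n(Cc3ccccc3)c2=O)c1` is the only member of the series with a number in an assay on cells for activation of Cystic fibrosis transmembrane conductance regulator (Homo sapiens), read by fluorescence, with a stated time of 10 min (a higher number here means that more compound is needed for the effect, a lower number that less compound is needed), where compound 1 gives 9900 nM. Compound 2 `O=C(O)c1ccc([N+](=O)[O-])c(-c2nc3ccccc3n(Cc3ccccc3)c2=O)c1` differs from it by hydrogen in place of methyl on an oxygen next to a carbonyl group. In this assay compound 2 reaches only a limit, > 10000 nM. The step of a number no lower from compound 1 to compound 2 (the limit leaves the size open) therefore has no readable size, since it ends at the limit of > 10000 nM in this assay, at which 1 of the 2 values shown sits.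

Compound 3 `COC(=O)c1ccc(N)c(-c2nc3ccccc3n(Cc3ccccc3)c2=O)c1` carries the change (amino in place of nitro on an aromatic carbon), amino in place of nitro on an aromatic carbon. Among the compounds with values here, no measured step touches this position, and the single step, from compound 1 to compound 2, gave no readable size. No shift beyond the scatter is expected for a 1.1-fold lower number from compound 1 to compound 3 (0.04 log units; within the scatter). Compound 3 is expected near 9000 nM, within 2500 nM to 30000 nM, with a fair chance that only a limit is reported.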

Compound 3, half-maximal effective concentration: 550 nM
Compound 3: the middle estimate sits 16-fold (1.21 log units) above what was measured; measured number below the stated range.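

In this assay, going by these compounds alone, the aromatic carbon para to a methoxycarbonyl group proves sensitive to its substituent: amino in place of nitro gives an 18-fold lower number from compound 1 to compound 3 (1.26 log units; beyond the scatter), and this is the first step with a readable size. Within the data shown here, the only earlier change lay at the ester and ended in a limit, so it said nothing about this position. Compound 3 keeps the methoxycarbonyl group and the core of compound 1, so the lower number comes with this single change on the aryl.

Nothing measured here accounts for the size of the step. The compounds shown leave open whether a methylamino group, an acetamido group or a hydroxyl group at this carbon keeps the lower number, and whether an amide in place of the methyl ester does so alongside the amino group.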